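Rearranged Bicyclic Sulfonamide Tested Against Rabbit Factor X

This account rests on a few compounds, and the source may have more. Where it says the series, first, only, none or still open, it means among the compounds named here.

Measured compounds:
compound 1 `O=C1[C@@H](NS(=O)(=O)c2cc3cccnc3s2)CCN1CCNc1ccncc1` gives 23%
compound 2 `Cc1c(S(=O)(=O)N[C@H]2CCN(Cc3cc4cc[nH]cc-4n3)C2=O)sc2ccc(Cl)cc12` gives 52%
compound 3 `O=C1[C@@H](NS(=O)(=O)c2cc3ccc(Cl)nc3s2)CCN1Cc1cc2[nH]cccc-2n1` gives 23%

In an assay on isolated protein for inhibition of coagulation factor X (Oryctolagus cuniculus), tested at 1 uM (on this read-out higher numbers stand for more inhibition at the one concentration tested (going by the name of the read-out) and lower numbers for less inhibition), compound 3 gives 23%, level with compound 1 at the digits shown, and together these two are the lowest of the three numbers; compound 2 sits a number higher, beyond the scatter. Compound 4 `O=C1[C@@H](NS(=O)(=O)c2cc3ccnc(Cl)c3s2)CCN1Cc1cc2[nH]cccc-2n1` has the same atoms as compound 3, joined differently: a group of 10 heavy atoms (7 carbon, 1 nitrogen, 1 sulfur, 1 chlorine; one five-membered aromatic ring with 1 hetero atom, one six-membered aromatic ring with 1 hetero atom) in place of a group of 10 heavy atoms (7 carbon, 1 nitrogen, 1 sulfur, 1 chlorine; one five-membered aromatic ring with 1 hetero atom, one six-membered aromatic ring with 1 hetero atom), on a sulfonyl sulfur. Among the compounds with values here, no pair of measured compounds in this set shares this kind of change, so no step of known size is available to lean on. Within the data shown here, compound 3 is therefore the only anchor for compound 4, and the expected step from compound 3 to compound 4 in this assay is a number 2 percentage points higher from compound 3 to compound 4 (within the scatter), a step not expected to go beyond the scatter in either direction. On that basis compound 4 is estimated to give 25% in this assay, in a range from 5% to 50%.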

Compound 4, a percentage reported as inhibition, at one concentration (the size of the read-out at that concentration, not a potency): 45%
Beside the measured number, compound 4's estimate is 20 percentage points below it; the range from low to high includes it.
By their numbers in this assay, from the lowest: compounds 1 and 3 (each within the scatter of the next); then compounds 4 and 2 (each within the scatter of the next).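

In this assay, within the data shown here, rejoining the atoms of the group on the sulfonyl sulfur, with none gained or lost, gives a number 22 percentage points higher from compound 3 to compound 4 (beyond the scatter), the first step in this set that can be read. This position therefore responds to how the group is joined, and not only to which atoms it holds, since the two groups match in heavy atoms, aromatic rings, hydrogen-bond donors and acceptors, and charge. Nothing available here explains the size of this step.

On these data alone, the step rests on a single pair, so whether the same rearrangement would carry over to the side chain of compound 1 remains open. As far as these compounds go, it also remains open whether a methoxy group or an amine in place of the chlorine would keep the number seen for compound 4 45%.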